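Glycinamide truncation in the chloroquinolinone amide series

The compounds below may be only part of what the source reports. "The series", "measured", "known", "first", "only" and "open" are said of these compounds alone.

Compound 1 `CC(C)N[C@H](C(=O)Nc1cc2cc[nH]c(=O)c2cc1Cl)C1CCCCC1` gives 190 nM in a functional assay (aorta) with Rattus norvegicus as the target; on this read-out lower numbers stand for an effect already at smaller amounts and higher numbers for an effect only at larger amounts of compound. Compound 2 `CC(C)(C)C[C@H](N)C(=O)Nc1cc2cc[nH]c(=O)c2cc1Cl` shares the core and in this assay gives "not determined" (no result reported), so no number anchors its position; compound 3 `CN(C)[C@H]1CC[C@@H](C(=O)Nc2cc3cc[nH]c(=O)c3cc2Cl)CC1` likewise gives "not determined" (no result reported). Compound 2 therefore stands nowhere on the numbers shown, and only compound 1 fixes the scale. Compound 4 `NCC(=O)Nc1cc2cc[nH]c(=O)c2cc1Cl` differs from compound 2 by hydrogen in place of neopentyl on a saturated chain carbon bound to an amine nitrogen and a carbonyl carbon, the same difference read one bond further out being 1-amino-3,3-dimethylbutyl to aminomethyl. Within the data shown here, no measured step of this kind exists. In this assay the step is expected to move the number upward, beyond the scatter, toward an effect only at larger amounts. Compound 4 is estimated at 2500 nM, within 400 nM to 15000 nM.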

Compound 4, half-maximal effective concentration: 2500 nM
Beside the measured number, compound 4's estimate shows no gap at the digits printed, and the stated range covers the measured number.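

In this assay compound 4 gives 2500 nM and compound 2 has no single number, so no new step can be read. As far as these compounds go, what neopentyl in place of hydrogen does to the number stays open. No available evidence bears on a cause for this result.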